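Swapping 2-hydroxyethyl for cyclopropyl on a shared core

The source may report more compounds than this note shows. Statements on the series, on what has been measured and on what is new or still open speak of the compounds shown alone.

- Compound 1 `COCc1nc2nc(C)cc(Nc3ccc(C(F)(F)F)cc3)n2n1`: 6.7 mL.min-1.g-1
- Compound 2 `Cc1cc(Nc2ccc(C(F)(F)F)cc2)n2nc(CCO)nc2n1`: < 5 mL.min-1.g-1
- Compound 3 `COCCc1nc2nc(C)cc(Nc3ccc(S(F)(F)(F)(F)F)cc3)n2n1`: 11.5 mL.min-1.g-1

These three compounds were tested in an in vitro ADME assay on microsomes from liver (Homo sapiens) for metabolic stability; a lower number here means slower removal, a higher number faster removal of the compound. In this assay compound 2 gives < 5 mL.min-1.g-1, which is a limit of the assay and not a number. Compound 2 therefore stands at the limit of < 5 mL.min-1.g-1 in this assay, at which 1 of the 3 values shown sits, and the other two compounds have true numbers.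

The next compound, compound 4 `Cc1cc(Nc2ccc(C(F)(F)F)cc2)n2nc(C3CC3)nc2n1`, has not been measured yet. It carries cyclopropyl in place of 2-hydroxyethyl on an aromatic carbon.

Within the data shown here, only one measured step touches this chain, an at least 1.3-fold lower number from compound 1 to compound 2 (0.12 log units; that floor lies within the scatter). Among the measured compounds shown here, it replaces methoxy with hydroxymethyl, so it is only a rough guide, and no measured compound carries cyclopropyl. Among these three compounds, the ones without a hydroxy group have true numbers: compound 1 gives 6.7 mL.min-1.g-1 and compound 3 gives 11.5 mL.min-1.g-1. Compound 3 also differs from compound 2 in a second place, so it counts for less, and compound 1 serves as the main guide.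

A modest rise is therefore expected, and the expected step is an at least 1.6-fold higher number from compound 2 to compound 4 (0.20 log units; that floor lies within the scatter). For compound 4 the estimated value is 8 mL.min-1.g-1, with an expected range of 5 mL.min-1.g-1 to 16 mL.min-1.g-1.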

Compound 4, intrinsic clearance in microsomes: < 5 mL.min-1.g-1
Compound 4: no number, only a limit; the forecaster's own chance of this, stated with the estimate: 20%; at least 1.6-fold (0.20 log units) between middle value and limit.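

In this assay compound 4 gives < 5 mL.min-1.g-1, which is a limit of the assay and not a number, and it shows that a hydroxy group is not required to reach that limit: cyclopropyl, with 0 hydrogen-bond donors and 0 hydrogen-bond acceptors, gets there from the same place, on an aromatic carbon between two ring nitrogen atoms. Among these compounds, until now compound 2 was the only compound at a limit, and replacing methoxymethyl with cyclopropyl gives an at least 1.3-fold lower number from compound 1 to compound 4 (0.12 log units; that floor lies within the scatter), so this comparison alone does not establish a real difference. The step from compound 2 to compound 4 cannot be read, and neither group can be placed ahead of the other, because both compounds sit at a limit: the limit of < 5 mL.min-1.g-1 in this assay, at which 2 of the 4 values shown sit.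

From the compounds shown here alone, it remains open whether an amine, a carboxylic acid or a longer chain at this place would keep the number at the limit or lift it to a true value. Also open, going by these compounds, is whether cyclopropyl would do the same on the shared core with pentafluorosulfanyl in place of trifluoromethyl.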